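The source may hold more compounds than are shown below. What is called first, only, known or untested is meant among the compounds shown, and "the series" means these compounds.

The measured compounds in this series are:

Compound 1: `O=C(Nc1cccc(Oc2ccccn2)c1)C1CCCN(C(=O)c2cc(C(F)(F)F)cc(C(F)(F)F)c2)C1`, 0%
Compound 2: `CC(C)(C)OC(=O)c1cccc(NC(=O)C2CCCN(C(=O)c3cc(C(F)(F)F)cc(C(F)(F)F)c3)C2)c1`, 0%
Compound 3: `CSc1cccc(NC(=O)C2CCCN(C(=O)c3cc(C(F)(F)F)cc(C(F)(F)F)c3)C2)c1`, 0%

All three share one core and differ only in the group that sits on the aromatic ring attached to the amide nitrogen. In an ADME assay on PC-3 cells (Homo sapiens) for cytotoxicity, read by WST assay, tested at 100 uM (on this read-out higher numbers stand for more inhibition at the one concentration tested (going by the name of the read-out) and lower numbers for less inhibition), compound 3 stands level with compounds 1 and 2. The step of no change at the digits printed from compound 1 to compound 2 (within the scatter), the step of no change at the digits printed from compound 1 to compound 3 (within the scatter) and the step of no change at the digits printed from compound 2 to compound 3 (within the scatter) all lie within the scatter, so none of the three exchanges on that aromatic carbon has shifted the read-out.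

Compound 4 is `O=C(Nc1ccc(Cl)cn1)C1CCCN(C(=O)c2cc(C(F)(F)F)cc(C(F)(F)F)c2)C1`. Its difference from compound 3 is 5-chloropyridin-2-yl in place of 3-(methylsulfanyl)phenyl on an amide-type nitrogen. Here the whole ring on the amide-type nitrogen is exchanged, not just one group on it, which reaches further than any of the three measured steps. Among the measured compounds shown here, still, those steps are the only guide: each of them replaced one substituent on that ring and each gave no change beyond the scatter, and all three values sit at the bottom of the read-out.

On that basis compound 4 is expected to show no step beyond the scatter, no change at the digits printed from compound 3 to compound 4 (within the scatter). The estimate for compound 4 in this assay is 0%, with a range from -8% to 10%.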

Compound 4, a percentage reported as inhibition, at one concentration (the size of the read-out at that concentration, not a potency): 0%
Estimate against measurement, compound 4: no gap at the digits printed, and the stated range covers the measured number.
By their numbers in this assay, from the lowest: compounds 1, 2, 3 and 4 (each within the scatter of the next).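

In this assay, the exchange of the whole 3-(methylsulfanyl)phenyl for 5-chloropyridin-2-yl on the amide-type nitrogen gives no change at the digits printed from compound 3 to compound 4 (within the scatter) and so leaves the read-out where the smaller exchanges left it. The earlier steps shown here swapped only one substituent on a six-membered aromatic ring of carbon only, whereas this one changes the ring attached to the amide-type nitrogen itself, bringing in a ring with a hetero atom, a chlorine and no sulfur, and the value stays the same at the digits printed. Nothing measured here accounts for this lack of any shift.

With all four compounds level in this assay, the series does not yet show that any exchange at this position can move the read-out, so what is left open is whether a group of another kind on the ring, such as an aliphatic amine or a carboxylic acid, would do so. As far as these compounds go, it is also open whether replacing a trifluoromethyl group on the other aromatic ring, for instance with a methoxy group or a hydrogen, would change the picture, since all four compounds carry the same shared core.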